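A Nitro Group Replaces Fluorine on the Phenyl Ring

The source may report more compounds than this note shows. Statements on the series, on what has been measured and on what is new or still open speak of the compounds shown alone.

In a functional assay on HepG2 cells (Homo sapiens) for antiproliferative activity, read by MTT assay, with a stated time of 48 h (a lower number here means a stronger inhibitor, a higher number a weaker inhibitor), compound 1 `CC(=O)N1N=C(c2ccc3ccccc3c2)OC1c1ccc(Cl)cc1` gives 1.88 ug/mL and compound 2 `CC(=O)N1N=C(c2ccc3ccccc3c2)OC1c1cccc(F)c1` gives 1.86 ug/mL, so compound 2 stands level with compound 1. Within the data shown here, the only measured step, a 1.0-fold lower number from compound 1 to compound 2 (0.00 log units; within the scatter), also exchanged the substituted phenyl on this carbon. Compound 3 `CC(=O)N1N=C(c2ccc3ccccc3c2)OC1c1ccccc1[N+](=O)[O-]` has 2-nitrophenyl in place of 3-fluorophenyl on a saturated ring carbon. One step within the scatter is thin evidence, but no shift beyond the scatter is expected in this assay. The expected change is a 1.1-fold higher number from compound 2 to compound 3 (0.03 log units; within the scatter). Compound 3 is estimated at 2 ug/mL, with an expected range of 0.8 ug/mL to 5.5 ug/mL.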

Compound 3, half-maximal inhibitory concentration: 12.3 ug/mL
Beside the measured number, compound 3's estimate is 6.2-fold (0.79 log units) below it, outside the stated range (above it).
By their numbers in this assay, from the lowest: compounds 2 and 1 (each within the scatter of the next); then compound 3.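

This position is not indifferent to what it carries: the exchange of one substituted phenyl for another that left the number in place before now gives a 6.6-fold higher number from compound 2 to compound 3 (0.82 log units; beyond the scatter), and likewise a 6.5-fold higher number from compound 1 to compound 3 (0.82 log units; beyond the scatter), both beyond the scatter. In this assay, 2-nitrophenyl is thus the first group shown here to move the number, and it moves it towards a weaker inhibitor. No measurement shown explains this shift. The nitro group and its place on the phenyl changed together, so their contributions cannot be separated. Going by these compounds, how 4-nitrophenyl or 2-aminophenyl would read remains open.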